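Hydroxy to Methoxy Change on a Shared Core

A few compounds are considered here, and "the series" means these few. Any claim that something is new, unique, unknown or untested is made for them only; others in the source may bear on it.

Measured compounds:
Compound 1, `COc1ccc([C@H]2c3cccc(c3O)NC(=O)/C(C)=C/C=C\[C@H](OC)[C@@H](OC(N)=O)/C(C)=C/[C@H](C)[C@@H](O)[C@@H](OC)C[C@@H]2C)cc1` — 450 nM
Compound 2, `COc1ccc([C@H]2c3cccc(c3O)NC(=O)/C(C)=C/C=C\[C@H](OC)[C@@H](OC(N)=O)/C(C)=C/[C@H](C)[C@@H](OC)[C@@H](OC)C[C@@H]2C)cc1` — 2560 nM
Compound 3, `COc1ccc([C@H]2c3cccc(c3O)NC(=O)/C(C)=C/CC[C@H](OC)[C@@H](OC(N)=O)/C(C)=C/[C@H](C)[C@@H](O)[C@@H](OC)C[C@@H]2C)cc1` — > 20000 nM

All three were tested in a functional assay on A-375 cells (Homo sapiens) for antiproliferative activity, read by MTT assay, with a stated time of 96 h; on this read-out lower numbers stand for stronger inhibition and higher numbers for weaker inhibition. Compound 1 and compound 2 differ by a single change, (methyl in place of hydrogen on an oxygen on a saturated carbon), and this change gave a 5.7-fold higher number from compound 1 to compound 2 (0.76 log units; beyond the scatter). For compound 3 the read-out stops at a limit rather than a number: compound 3 sits at the limit of > 20000 nM in this assay, at which 1 of the 3 values shown sits. How the core of compound 3 differs from the core of compound 1 is not broken down here.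

Compound 4, `COc1ccc([C@H]2c3cccc(c3O)NC(=O)/C(C)=C/CC[C@H](OC)[C@@H](OC(N)=O)/C(C)=C/[C@H](C)[C@@H](OC)[C@@H](OC)C[C@@H]2C)cc1`, has not yet been measured. Among the compounds with values here, it differs from compound 3 by methyl in place of hydrogen on an oxygen on a saturated carbon, which is the same change as the one from compound 1 to compound 2, made at the same place in the same words. Among the compounds shown this change occurs twice in all.

Compound 4 is expected to give 50000 nM in this assay, most likely between 20000 nM and 200000 nM. That expectation rests on two points: compound 3 already gives only a limit, > 20000 nM, and the same change weakened compound 2 against compound 1 because a 5.7-fold higher number from compound 1 to compound 2 (0.76 log units; beyond the scatter) lay beyond the usual scatter. The step this estimate implies is a step that the limit leaves unreadable from compound 3 to compound 4, and it is expected that the assay will again report only a limit for compound 4.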

Compound 4, half-maximal inhibitory concentration: > 20000 nM
Compound 4: a limit, no number; the forecaster's own chance of this, stated with the estimate: 90%; the middle value is on the limit's open side.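

In this assay compound 4 gives > 20000 nM as a limit, not a number. Compound 3 also stands at a limit, so no step from compound 3 to compound 4 can be read: the limit of > 20000 nM in this assay, at which 2 of the 4 values shown sit.

Whether the same change of hydroxy to methoxy, seen as a 5.7-fold higher number from compound 1 to compound 2 (0.76 log units; beyond the scatter), has any counterpart on the core of compound 3 is what the compounds shown leave open.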